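Cytotoxicity limits in a three-compound series and a fourth

The source may report more compounds than this note shows. Statements on the series, on what has been measured and on what is new or still open speak of the compounds shown alone.

Measured compounds in an ADME assay on Raji cells (Homo sapiens) for cytotoxicity, read by CellTiter-Glo and resazurin assay, with a stated time of 72 h (a higher number here means that more compound is needed for the effect, a lower number that less compound is needed), each value being a limit of the assay rather than a number:
compound 1 `CC(C)N(Cc1cccc(OCCCCCC(=O)O)c1)C(=O)c1ccc(-c2cccc(O)c2)cc1`: > 26000 nM.
compound 2 `CC(C)N(Cc1cccc(OCCCCCC(=O)O)c1)C(=O)c1ccc(-c2cccc(OC(F)(F)F)c2)cc1`: > 26000 nM.
compound 3 `CCOC(=O)CCCCCOc1cccc(CN(C(=O)c2ccc(-c3cccc(O)c3)cc2)C(C)C)c1`: > 26000 nM.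

For compound 1 the result is a limit. For compound 2 the result is likewise a limit. For compound 3 the result is also a limit. Nothing beyond that is known of any of the three in this assay.

From compound 1 to compound 2 the change is trifluoromethyl in place of hydrogen on an oxygen on an aromatic ring. The step that the two limits leave unreadable from compound 1 to compound 2 is unreadable because of the limit of > 26000 nM in this assay, at which 3 of the 3 values shown sit. From compound 1 to compound 3 the change is ethyl in place of hydrogen on an oxygen next to a carbonyl group, and the step that the two limits leave unreadable from compound 1 to compound 3 is unreadable for the same reason, because of the limit of > 26000 nM in this assay, at which 3 of the 3 values shown sit.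

Compound 4 `CCOC(=O)CCCCCOc1cccc(CN(C(=O)c2ccc(-c3cccc(OC(F)(F)F)c3)cc2)C(C)C)c1` is not yet measured. It differs from compound 3 by trifluoromethyl in place of hydrogen on an oxygen on an aromatic ring, which is the same change, at the same place, as that from compound 1 to compound 2. On that pairing the expected step that the limit leaves unreadable from compound 3 to compound 4 is one the limit would again hide. Compound 4 is expected near 30000 nM, within 20000 nM to 80000 nM, most likely reported as a limit once more.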

Compound 4, half-maximal effective concentration: > 26000 nM
Compound 4 gave a limit, no number (the forecaster's own chance of this, stated with the estimate: 85%); the middle value does not contradict the limit.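

No new step can be read from compound 3 to compound 4 or from compound 2 to compound 4, because both ends of each step are limits rather than numbers: the limit of > 26000 nM in this assay, at which 4 of the 4 values shown sit.

Still open, from the compounds shown here alone, is whether either change, trifluoromethyl or ethyl in place of hydrogen, shifts the half-maximal effective concentration of compound 1, compound 2, compound 3 or compound 4 in this assay at all.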